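Pyrazole substituent variation on a shared kinase inhibitor core

The source may report more compounds than this note shows. Statements on the series, on what has been measured and on what is new or still open speak of the compounds shown alone.

For the measured compounds named here, compound 2 `Cc1c(Nc2nc(N)c3c(C#N)c(N4CCC[C@H]4C)n(C)c3n2)cnn1C1COC1` is the only member of the series with a single number in an assay on isolated protein for inhibition of Leucine-rich repeat serine/threonine-protein kinase 2 variant G2019S (Homo sapiens), read by TR-FRET and LanthaScreen, with stated times of 50 min and 30 min, in the presence of a further agent that is not named here; a lower number here means a stronger inhibitor, a higher number a weaker inhibitor: compound 2 gives 37 nM, with one further entry that gave no single figure. Compound 1 `Cc1nn(C2CCOC2)cc1Nc1nc(N)c2c(C#N)c(N3CCC[C@H]3C)n(C)c2n1`, which carries an oxolanyl group in the corresponding position, gives 12 nM; 28 nM (2 entries) in this assay; the spread of its repeats the several entries of compound 1 in this assay, 12 nM; 28 nM (2 entries) shows how much the read-out moves from run to run. Compound 3 `Cc1nn(C)cc1Nc1nc(N)c2c(C#N)c(N3CCC[C@H]3C)n(C)c2n1` has not been measured. It differs from compound 2 by 1,3-dimethyl-1H-pyrazol-4-yl in place of 5-methyl-1-(oxetan-3-yl)-1H-pyrazol-4-yl on a nitrogen on an aromatic ring. Going by the values given here, no measured pair isolates this change, so the expectation rests on compound 2 and the scatter alone. The step from compound 2 to compound 3 is expected to be small, a 1.1-fold higher number from compound 2 to compound 3 (0.03 log units; within the scatter), likely within the scatter and without a clear direction. Compound 3 is therefore estimated at 40 nM in this assay, with a range of 15 nM to 120 nM.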

Compound 3, half-maximal inhibitory concentration: 30 nM
Estimate against measurement, compound 3: 1.3-fold (0.12 log units) above; the range from low to high includes it.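

In this assay the exchange gives a 1.2-fold lower number from compound 2 to compound 3 (0.09 log units; within the scatter), so 1,3-dimethyl-1H-pyrazol-4-yl and 5-methyl-1-(oxetan-3-yl)-1H-pyrazol-4-yl cannot be told apart in this read-out. For the compounds shown here, this is the first measured pair at this place, and it shows that the four-membered non-aromatic ring can leave with no difference beyond the scatter. The step is also smaller than the spread between repeats of a single compound: the several entries of compound 1 in this assay, 12 nM; 28 nM (2 entries)

Still open, going by these compounds, is whether a different kind of group on this nitrogen, such as an amine or a carboxylic acid, would give a step beyond the scatter. The ring methyl also carries a different number in the two group names, so this one step does not separate any contribution of the methyl from that of the oxetan-3-yl group.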